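Swapping the Diamine Tail on a Decylphenyl Oxadiazole Core

The source may hold more compounds than are shown below. What is called first, only, known or untested is meant among the compounds shown, and "the series" means these compounds.

Two compounds share a core and differ only in the chain on one carbon of the five-membered ring. Compound 1 `CCCCCCCCCCc1ccc(-c2noc([C@@H](N)CCN)n2)cc1` gives 14% in an assay on HeLa cells for inhibition of sphingosine-1-phosphate transporter SPNS2 (Mus musculus), read by LC-MS, tested at 2 uM; on this read-out higher numbers stand for more inhibition at the one concentration tested (going by the name of the read-out) and lower numbers for less inhibition. Among the compounds with values here, compound 2 `CCCCCCCCCCc1ccc(-c2noc([C@@H](N)CCCN)n2)cc1` gives 40% in the same assay, and the single step of a number 26 percentage points higher from compound 1 to compound 2 (beyond the scatter) makes compound 2 the higher of the two numbers measured so far.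

Compound 3 `CCCCCCCCCCc1ccc(-c2noc(CC(O)CN3CCCCC3)n2)cc1` is not yet measured. The change from compound 2 is 2-hydroxy-3-(piperidin-1-yl)propyl in place of 1,4-diaminobutyl on an aromatic carbon. Within the data shown here, no measured pair shows this kind of exchange; the only step available, a number 26 percentage points higher from compound 1 to compound 2 (beyond the scatter), concerns a lengthening of the same chain by one carbon, and it only loosely bears on a change that also replaces both amines with a hydroxyl and a piperidine ring. Among the measured compounds shown here, that step suggests a longer tail can carry a higher reading, but the loss of the amines has no precedent here.

Compound 3 is therefore expected to land near 35%, within a wide range of 5% to 75%, the estimated step of a number 5 percentage points lower from compound 2 to compound 3 (within the scatter) being uncertain in direction.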

Compound 3, a percentage reported as inhibition, at one concentration (the size of the read-out at that concentration, not a potency): 2%
The estimate for compound 3 lay 33 percentage points above the measured number; measured number outside the range, below it.
By their numbers in this assay, from the lowest: compound 3; then compound 1; then compound 2.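

The tail on this aromatic carbon of the five-membered ring clearly matters for more than its length. In this assay, placing 2-hydroxy-3-(piperidin-1-yl)propyl in place of 1,4-diaminobutyl gives a number 38 percentage points lower from compound 2 to compound 3 (beyond the scatter), and placing it in place of the shorter 1,3-diaminopropyl gives a number 12 percentage points lower from compound 1 to compound 3 (beyond the scatter), so a larger tail with a six-membered ring reads below both diamine tails and size alone does not carry the reading. No measurement on hand says why the reading falls.

This single exchange changes several features at once: the two nitrogens of the diamine tail give way to one ring nitrogen and a hydroxyl, and the chain gains a ring, so the compounds shown cannot say which of these changes accounts for the fall. A 3-amino-2-hydroxypropyl tail, which keeps the hydroxyl but has a simple amine instead of the piperidine, or a 1,5-diaminopentyl tail, which extends the diamine series by one more carbon, would be the kinds of group that could begin to separate these features.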